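Methyl to Ethyl on the Aryl of a Shared Core

This account rests on a few compounds, and the source may have more. Where it says the series, first, only, none or still open, it means among the compounds named here.

Compound 1, `Cc1ccccc1-n1nc(C)c2c1NC(=O)[C@H](C)S[C@@H]2c1ccc(Oc2ccccc2)cc1`: 1300 nM
Compound 2, `Cc1ccccc1-n1nc(C)c2c1NC(=O)[C@H](C)S[C@@H]2c1ccc(/C=C/c2ccccc2)cc1`: "not active" (no number reported)
Compound 3, `COC(=O)c1cccc(-c2ccc([C@H]3S[C@@H](C)C(=O)Nc4c3c(C)nn4-c3ccccc3C)cc2)c1`: "not active" (no number reported)

Among the measured compounds shown here, in an assay on isolated protein for agonist activity at Bile acid receptor (Homo sapiens), read by AlphaScreen, with a stated time of 30 min (a higher number here means that more compound is needed for the effect, a lower number that less compound is needed), compound 1 gives 1300 nM, the only number in this set. Compound 2 and compound 3 carry no number and are recorded as inactive, so compound 1 stands alone as the single quantified point. Compound 4, `CCc1ccccc1-n1nc(C)c2c1NC(=O)[C@H](C)S[C@@H]2c1ccc(Oc2ccccc2)cc1`, has not yet been measured. It differs from compound 1 by methyl in place of hydrogen on a saturated chain carbon bound to an aromatic carbon, a change of one carbon on the aryl group attached to the shared core. For the measured compounds named here, no measured pair describes such a step, so the expectation for compound 4 can rest only on compound 1. The step of a 1.2-fold lower number from compound 1 to compound 4 (0.07 log units; within the scatter) is expected to be small, no larger than the scatter, in no clear direction. Compound 4 is therefore estimated at 1100 nM, between 350 nM and 3500 nM.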

Compound 4, half-maximal effective concentration: 1100 nM
Estimate against measurement, compound 4: no gap at the digits printed, within the range that was stated.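

Going from 2-methylphenyl to 2-ethylphenyl in this assay gives a 1.2-fold lower number from compound 1 to compound 4 (0.07 log units; within the scatter), the first step in this set that can be read as a number. At this place on the aryl group of the shared core, methyl in place of hydrogen therefore leaves the reading indistinguishable from that of compound 1. Nothing shown accounts for this result. On these data alone, whether a longer chain such as propyl would also hold the reading remains open. So does the effect of an amine or a carboxylic acid at this place.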